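Swapping the benzyl substituent of compound 2 for a methoxy

The source may hold more compounds than are shown below. What is called first, only, known or untested is meant among the compounds shown, and "the series" means these compounds.

For the measured compounds named here, compound 2 `COc1cccc(OC)c1OCCNCCOc1ccccc1OCc1ccc(C)cc1` holds the higher of the two numbers measured so far in a functional assay on spleen for antagonist activity at Alpha-1B adrenergic receptor (Rattus norvegicus) (a higher number here means a more potent compound, by a factor of ten per unit of this negative logarithm, a lower number a less potent compound), where compound 2 gives 8.43. Going by the values given here, its nearest neighbour is compound 1 `COc1cccc(OC)c1OCCNCCOc1ccccc1OCc1ccc(Cl)cc1`, which in this assay gives 8.06; the single measured step, a number 0.37 log units higher from compound 1 to compound 2 (beyond the scatter), concerns the substituent on the same benzyl ring. Compound 3 `COc1cccc(COc2ccccc2OCCNCCOc2c(OC)cccc2OC)c1` differs from compound 2 by 3-methoxyphenyl in place of 4-methylphenyl on a saturated chain carbon bound to an oxygen on an aromatic ring. Among the compounds with values here, the one step on record touches that ring but exchanges chloro for methyl and was modest in size; nothing measured here covers the exchange of a methyl for a methoxy, nor the change of place that the names 4-methylphenyl and 3-methoxyphenyl tell. That step is therefore only a rough guide: a substituent change on this ring has so far moved this assay modestly, so a small change of uncertain direction is the most that can be expected, with a step expected to be a number 0.23 log units lower from compound 2 to compound 3 (within the scatter), within the scatter. Compound 3 is accordingly estimated at 8.2 in this assay, with a range from 7.6 to 8.8.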

Compound 3, negative logarithm of the antagonist equilibrium constant: 8.31
Compound 3: the middle estimate sits 0.11 log units below what was measured; the measured number falls inside the stated range.
By their numbers in this assay, from the lowest: compounds 1, 3 and 2 (each within the scatter of the next, the first and the last beyond it).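

In this assay the new group, 3-methoxyphenyl, gives a number 0.12 log units lower from compound 2 to compound 3 (within the scatter) and a number 0.25 log units higher from compound 1 to compound 3 (within the scatter) on the same saturated chain carbon bound to an oxygen on an aromatic ring. For the compounds shown here, this position therefore accepts a change in both the substituent and its place on the ring, including the added oxygen and hydrogen-bond acceptor, with neither step leaving the scatter, whereas the earlier exchange of groups at one place gave a number 0.37 log units higher from compound 1 to compound 2 (beyond the scatter) as the only step beyond it. Nothing independent of these numbers explains the result.

The two changes folded into this exchange remain unseparated, and a 4-methoxyphenyl or a 3-methylphenyl group at this carbon would be needed to tell the effect of the methoxy group from that of its place on the ring. Going by these compounds, it also remains open whether this tolerance extends to an unsubstituted phenyl, to a ring carrying an amine or a carboxylic acid, or to a longer chain between the ring and the oxygen.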